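Selenium-to-Sulfur Exchange Carried Onto a Second Core

The source may report more compounds than this note shows. Statements on the series, on what has been measured and on what is new or still open speak of the compounds shown alone.

Compound 1 `C[Se]/C(=N\C(=O)c1cccs1)NC(=O)c1cccs1` and compound 2 `CS/C(=N\C(=O)c1cccs1)NC(=O)c1cccs1` share one core and differ by a group of 2 heavy atoms (1 carbon, 1 sulfur; no ring) in place of a group of 2 heavy atoms (1 carbon, 1 selenium; no ring), on a carbon with a double bond to nitrogen. In an ADME assay on MCF-10A cells (Homo sapiens) for cytotoxicity, read by MTT assay, with a stated time of 72 h (a lower number here means a stronger inhibitor of growth, a higher number a weaker inhibitor of growth), compound 1 gives 9260 nM, while compound 2 gives 19700 nM, so this exchange made a 2.1-fold higher number from compound 1 to compound 2 (0.33 log units; beyond the scatter). Compound 3 `C[Se]/C(=N\C(=O)c1cnc2ccccc2c1)NC(=O)c1cnc2ccccc2c1` rests on another core; how the two cores differ is not broken down here. In this assay compound 3 gives 20300 nM, and its number and that of compound 2 lie within the scatter of each other. Compound 4 `CS/C(=N\C(=O)c1cnc2ccccc2c1)NC(=O)c1cnc2ccccc2c1` is compound 3 carrying the same change, (a group of 2 heavy atoms (1 carbon, 1 sulfur; no ring) in place of a group of 2 heavy atoms (1 carbon, 1 selenium; no ring), on a carbon with a double bond to nitrogen), at the same place. Since the first exchange gave a 2.1-fold higher number from compound 1 to compound 2 (0.33 log units; beyond the scatter), the step from compound 3 to compound 4 is expected to be of similar size, a 2.1-fold higher number from compound 3 to compound 4 (0.32 log units; beyond the scatter). On that basis compound 4 is expected to give about 42000 nM in this assay, within an estimated range from 20000 nM to 90000 nM.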

Compound 4, concentration for 50% growth inhibition: 500 nM
Beside the measured number, compound 4's estimate is 84-fold (1.92 log units) above it; the whole stated range lies above it.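

In this assay, putting methylsulfanyl in place of the selenium-bearing group gave a 41-fold lower number from compound 3 to compound 4 (1.61 log units; beyond the scatter), so the change did not carry from one core to the other in either direction or size: the same change on two cores in this assay, a 2.1-fold higher number (0.33 log units; beyond the scatter) from compound 1 to compound 2 and a 41-fold lower number (1.61 log units; beyond the scatter) from compound 3 to compound 4, 86-fold (1.94 log units) apart, beyond the scatter of two such steps. Within these two pairs, the result of this exchange therefore depends on the core that carries it. The two pairs do not show which part of the cores is responsible, why the direction reverses, or what the exchange would do on a third core.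

The compounds shown leave open how this assay would respond to a methoxy group, an amine or a longer chain such as ethylsulfanyl on the same carbon. They also leave open whether any such group would follow the pattern of compound 2 or that of compound 4.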